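This account rests on a few compounds, and the source may have more. Where it says the series, first, only, none or still open, it means among the compounds named here.

Measured in a functional assay on SK-OV-3 cells (Homo sapiens) for antiproliferative activity, read by MTT assay, with a stated time of 72 h; on this read-out higher numbers stand for weaker inhibition and lower numbers for stronger inhibition:
Compound 1 `O=C(CCc1cccc2c1B(O)OC2)Nc1cccc(-c2ccccc2)c1`: 250 nM
Compound 2 `O=C(CCc1cccc2c1B(O)OC2)Nc1cccc(-c2ccc(F)cc2)c1`: 93 nM
Compound 3 `O=C(CCc1cccc2c1B(O)OC2)Nc1cccc(-c2ccc(Cl)cc2)c1`: 220 nM

Compound 3, at 220 nM, cannot be told apart from the unsubstituted compound 1, as a 1.1-fold lower number from compound 1 to compound 3 (0.06 log units; within the scatter) shows. Compound 2 is the one that separates from this pair, and a 2.4-fold higher number from compound 2 to compound 3 (0.37 log units; beyond the scatter) puts compound 3 on the weaker side of it.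

The next compound, compound 4 `CSc1ccc(-c2cccc(NC(=O)CCc3cccc4c3B(O)OC4)c2)cc1`, has not yet been measured. It carries methylsulfanyl in place of chloro on an aromatic carbon, turning the 4-chlorophenyl into a 4-(methylsulfanyl)phenyl.

Going by the values given here, no measured step covers this exact exchange, so the reasoning rests on the nearest ones. Putting chloro in place of hydrogen gave a 1.1-fold lower number from compound 1 to compound 3 (0.06 log units; within the scatter), while fluoro in place of hydrogen gave a 2.7-fold lower number from compound 1 to compound 2 (0.43 log units; beyond the scatter). Exchanging fluoro for chloro gave a 2.4-fold higher number from compound 2 to compound 3 (0.37 log units; beyond the scatter). Changes at this place have therefore been modest at most across these three compounds, and the new group has no measured precedent. No step beyond the scatter is expected in this assay, in either direction.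

The expected change is a 1.2-fold lower number from compound 3 to compound 4 (0.09 log units; within the scatter). For compound 4 the estimate is 180 nM, with an expected range from 70 nM to 450 nM.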

Compound 4, half-maximal inhibitory concentration: 140 nM
Compound 4: middle estimate off by 1.3-fold (0.11 log units), on the high side; measured number inside the range.
By their numbers in this assay, from the lowest: compounds 2, 4, 3 and 1 (each within the scatter of the next, the first and the last beyond it).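

In this assay, going by these compounds alone, methylsulfanyl is the first group at this position with two heavy atoms and the first to bring a hydrogen-bond acceptor, and the steps of a 1.6-fold lower number from compound 3 to compound 4 (0.20 log units; within the scatter) and a 1.5-fold higher number from compound 2 to compound 4 (0.18 log units; within the scatter) and a 1.8-fold lower number from compound 1 to compound 4 (0.25 log units; within the scatter) all stay within the scatter. The earlier compounds shown here had split into two sides, with compound 2 separated from both compound 1 and compound 3, but compound 4 cannot be told apart from either side, so its exchange for chloro, fluoro or hydrogen registers as no real change in this assay. No measurement shown here bears on why the numbers at this position fall as they do.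

The compounds shown leave open whether the step beyond the scatter seen on going from compound 1 to compound 2 is particular to fluoro or is shared by other groups at this place, such as methoxy, an amine or a carboxylic acid. As far as these compounds go, it also remains open whether the sulfur atom of compound 4 counts for anything, which a comparison with methoxy or with a longer chain such as ethylsulfanyl could begin to show.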